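A few compounds are considered here, and "the series" means these few. Any claim that something is new, unique, unknown or untested is made for them only; others in the source may bear on it.

Notes on the series. Compound 1 `C=CCOC1=CS(=O)(=O)OC1(CC)Cc1ccccc1` and compound 2 `CCC1(Cc2ccccc2)OS(=O)(=O)C=C1OCc1ccc(Br)cc1` share one core and differ at a single point. In an ADME assay on HEL cells (Homo sapiens) for cytotoxicity, with a stated time of 3 days (a lower number here means that less compound is tolerated, a higher number that more compound is tolerated), compound 1 gives 80000 nM, and in the same run compound 2 gives 80000 nM. The step of no change at the digits printed from compound 1 to compound 2 (within the scatter), 4-bromophenyl in place of vinyl on a saturated chain carbon bound to an oxygen on an unsaturated carbon, stays within the scatter. Compound 2 thus stands level with compound 1 on the minimum cytotoxic concentration; nothing separates the two beyond the scatter.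

Compound 3 `CCC1(Cc2ccccc2)OS(=O)(=O)C=C1OC(=O)c1ccccc1` is not yet measured. It differs from compound 2 by benzoyl in place of 4-bromobenzyl on an oxygen on an unsaturated carbon. Among the compounds with values here, only one measured step bears on this change, no change at the digits printed from compound 1 to compound 2 (within the scatter), which altered the group on the same oxygen and was flat. Within the data shown here, no measured step puts a benzoyl on that oxygen, so the pair offers no sign of movement. No step beyond the scatter is expected, and the step from compound 2 to compound 3 is estimated as no change at the digits printed from compound 2 to compound 3 (within the scatter). Compound 3 is expected to give 80000 nM in this assay, with a range from 30000 nM to 160000 nM.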

Compound 3, minimum cytotoxic concentration: > 400000 nM
Compound 3: a limit, no number (the forecaster's own chance of this, stated with the estimate: 20%); middle value at least 5.0-fold (0.69 log units) from the limit.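

On the oxygen on an unsaturated carbon, the group does matter in this assay: with benzoyl at this position the read-out shifts, an at least 5.0-fold higher number from compound 2 to compound 3 (0.69 log units; beyond the scatter) and an at least 5.0-fold higher number from compound 1 to compound 3 (0.69 log units; beyond the scatter), whereas the earlier pair gave only no change at the digits printed from compound 1 to compound 2 (within the scatter). Among these three compounds, allyl and 4-bromobenzyl read alike, and only benzoyl, which brings a carbonyl onto that oxygen, separates from them, with more compound tolerated. For compound 3 the value is a limit and not a number, so both steps are bounded on one side only: the limit of > 400000 nM in this assay, at which 1 of the 3 values shown sits.

The compounds shown cannot tell whether the shift follows the carbonyl on that oxygen or the benzoyl group as a whole, since the aromatic ring is present in both compound 2 and compound 3; an acetyl or a phenylacetyl group at the same place would separate the two readings. Going by these compounds, it also stays open whether a 4-bromobenzoyl group would keep the shift, and how far the tolerated concentration of such esters lies past the limit.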